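This account rests on a few compounds, and the source may have more. Where it says the series, first, only, none or still open, it means among the compounds named here.

Measured in a functional assay on A-375 cells (Homo sapiens) for cytotoxicity, read by MTT assay, with a stated time of 72 h; on this read-out lower numbers stand for stronger inhibition and higher numbers for weaker inhibition:
- compound 1 `O=C1c2c[n+]([O-])c3ccccc3c2C(=O)c2c1c1ccccc1n2Cc1cn([C@H]2O[C@H](CO)[C@@H](O)[C@H]2O)nn1`: 340 nM
- compound 2 `CC1(C)OC[C@H](Cn2cc(Cn3c4c(c5ccccc53)C(=O)c3c[n+]([O-])c5ccccc5c3C4=O)nn2)O1`: 180 nM

For the measured compounds named here, on these numbers, compound 2 at 180 nM stands level with compound 1, the only other compound measured, since the gap between them lies within the scatter. The next compound, compound 3 `CC1(C)OC[C@@H](Cn2cc(Cn3c4c(c5ccccc53)C(=O)c3c[n+]([O-])c5ccccc5c3C4=O)nn2)O1`, awaits measurement in this assay. The change is confined to one place: the two compounds have the same atoms and bonds and differ only in configuration as drawn: 1 of 1 stereo elements differ; a stereocentre at a saturated ring carbon is drawn S in compound 2 and R in compound 3. Going by the values given here, no measured pair differs in configuration alone, so the data give no direct measure of such a change. Among the compounds with values here, the one measured step bears on it only indirectly. That step, a 1.9-fold lower number from compound 1 to compound 2 (0.28 log units; within the scatter), exchanges 3,4-dihydroxy-5-(hydroxymethyl)oxolan-2-yl for (2,2-dimethyl-1,3-dioxolan-4-yl)methyl on an aromatic nitrogen, and even this replacement of a whole group stays within the scatter. With no evidence for a direction, no shift beyond the scatter is expected, and the estimated result is a 1.1-fold higher number from compound 2 to compound 3 (0.05 log units; within the scatter). Compound 3 is therefore expected at 200 nM, with an estimated range from 90 nM to 450 nM.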

Compound 3, half-maximal inhibitory concentration: 450 nM
The estimate for compound 3 lay 2.3-fold (0.35 log units) below the measured number; the measured number falls inside the stated range.
By their numbers in this assay, from the lowest: compounds 2, 1 and 3 (each within the scatter of the next, the first and the last beyond it).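

In this assay, for the compounds shown here, this is the first measured change of configuration alone, and a 2.5-fold higher number from compound 2 to compound 3 (0.40 log units; beyond the scatter) is modest but beyond the scatter. The configuration drawn at this saturated ring carbon therefore matters to the read-out, with the S form of compound 2 giving the lower number, and the step can be assigned to that one stereocentre for a plain reason: the fact that compounds 2 and 3 differ only in the configuration as drawn. Exchanging the whole group on the aromatic nitrogen, by contrast, separates neither form from compound 1: a 1.9-fold lower number from compound 1 to compound 2 (0.28 log units; within the scatter) and a 1.3-fold higher number from compound 1 to compound 3 (0.12 log units; within the scatter) both stay within the scatter, so the only clear difference among these three compounds is the one between the two configurations.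

What the compounds shown leave open is whether this preference for the S form is a general feature of the position or is tied to the (2,2-dimethyl-1,3-dioxolan-4-yl)methyl group, as a single pair cannot separate the two. Going by these compounds, it also remains unknown how the number would respond if an amine or a longer chain stood in place of that group on the aromatic nitrogen, in either configuration.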